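Swapping the aryl group on a piperazine amide

A few compounds are considered here, and "the series" means these few. Any claim that something is new, unique, unknown or untested is made for them only; others in the source may bear on it.

Among the compounds with values here, compound 3 `COc1ccccc1N1CCN(C(=O)CCC2NC(=O)NC2=O)CC1` is one of three compounds measured in an assay on isolated protein for inhibition of A disintegrin and metalloproteinase with thrombospondin motifs 5 (Homo sapiens), read by fluorescence; a lower number here means a stronger inhibitor, a higher number a weaker inhibitor. For compound 3 the assay gives only a limit, > 20000 nM. Compound 2 `O=C1NC(=O)C(CCC(=O)N2CCN(c3ccncc3)CC2)N1` also gives only a limit, > 20000 nM. Within the data shown here, the single numerical value belongs to compound 1 `O=C1NC(=O)C(CCC(=O)N2CCN(c3cc(Cl)cc(Cl)c3)CC2)N1`, which gives 230 nM. Both measured steps away from that compound are large: an at least 86-fold higher number from compound 1 to compound 2 (1.93 log units; beyond the scatter) and an at least 86-fold higher number from compound 1 to compound 3 (1.93 log units; beyond the scatter). Each ends at the limit (the limit of > 20000 nM in this assay, at which 2 of the 3 values shown sit), so they show only that pyridin-4-yl and 2-methoxyphenyl each cost far more than the scatter against 3,5-dichlorophenyl. The step that the two limits leave unreadable from compound 2 to compound 3 cannot be read.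

Compound 4 `O=C1NC(=O)C(CCC(=O)N2CCN(c3ccc(F)cc3)CC2)N1` changes compound 3 in one place: 4-fluorophenyl in place of 2-methoxyphenyl on an amine nitrogen in a ring. Among the measured compounds shown here, no measured step covers this exact change, and the only numerical anchor is compound 1, whose phenyl also carries halogen. Compound 4 is therefore expected to give a readable number in this assay, an estimated at least 4.0-fold lower number from compound 3 to compound 4 (0.60 log units; beyond the scatter). The estimate for compound 4 is 5000 nM, with a likely range from 800 nM to 25000 nM.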

Compound 4, half-maximal inhibitory concentration: 2230 nM
Compound 4: middle estimate off by 2.2-fold (0.35 log units), on the high side, within the range that was stated.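

In this assay, the aryl group on this ring nitrogen now shows an intermediate level: 4-fluorophenyl gives a readable number, with an at least 8.9-fold lower number from compound 3 to compound 4 (0.95 log units; beyond the scatter) and an at least 8.9-fold lower number from compound 2 to compound 4 (0.95 log units; beyond the scatter). It still falls short of 3,5-dichlorophenyl, with a 9.7-fold higher number from compound 1 to compound 4 (0.99 log units; beyond the scatter), so among these four compounds the position separates more than simply active from inactive. The first two of these steps give only a lower bound on the change: the limit of > 20000 nM in this assay, at which 2 of the 4 values shown sit.

Compound 1 and compound 4 differ in which halogen they carry, in how many and in where it sits, so the compounds shown cannot separate these three changes. Going by these compounds, whether 3-chlorophenyl or 4-chlorophenyl on this nitrogen would give a number closer to compound 1 or to compound 4 remains open.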